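From 3-Methylphenyl to 3-Nitrophenyl

The source may report more compounds than this note shows. Statements on the series, on what has been measured and on what is new or still open speak of the compounds shown alone.

Going by the values given here, in a functional assay on SGC-7901 cells (Homo sapiens) for antiproliferative activity, read by MTT assay, with a stated time of 72 h (on this read-out lower numbers stand for stronger inhibition and higher numbers for weaker inhibition), compound 1 (`COc1cc(-n2cnc3ccc(-c4ccccc4)cc32)cc(OC)c1OC`) gives 290 nM and compound 2 (`COc1cc(-n2cnc3ccc(-c4cccc(C)c4)cc32)cc(OC)c1OC`) gives 1240 nM as the higher of the two numbers so far. Compound 3 (`COc1cc(-n2cnc3ccc(-c4cccc([N+](=O)[O-])c4)cc32)cc(OC)c1OC`) has nitro in place of methyl on an aromatic carbon with the rest of compound 2 unchanged. Among the compounds with values here, only one measured step bears on this carbon: methyl in place of hydrogen gave a 4.3-fold higher number from compound 1 to compound 2 (0.63 log units; beyond the scatter) as a modest change. Within the data shown here, that step shows the number can move with a change at this place, but no measured compound carries nitro, so it gives only a weak guide to direction. A slight drop from compound 2 is expected, with no shift beyond the scatter. The expected step is a 1.4-fold lower number from compound 2 to compound 3 (0.14 log units; within the scatter) in this assay on this reasoning. The estimate for compound 3 is 900 nM with 250 nM to 3000 nM as its expected range.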

Compound 3, half-maximal inhibitory concentration: 380 nM
The estimate for compound 3 lay 2.4-fold (0.37 log units) above the measured number; the measured number falls inside the stated range.
By their numbers in this assay, from the lowest: compounds 1 and 3 (each within the scatter of the next); then compound 2.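

In this assay the change from 3-methylphenyl to 3-nitrophenyl gives a 3.3-fold lower number from compound 2 to compound 3 (0.51 log units; beyond the scatter) and so shows that the higher number seen with methyl does not hold for every group on this carbon. Nitro in place of hydrogen gives a 1.3-fold higher number from compound 1 to compound 3 (0.12 log units; within the scatter) and leaves compound 1 and compound 3 within the scatter of each other, so a group at this place need not raise the number as methyl did in compound 2. Nothing available explains why methyl and nitro differ at this carbon.

On these data alone, whether this outcome is particular to nitro or would also appear with another group here, such as an amine or a carboxylic acid, stays open. The compounds shown carry methyl and nitro at this one place only, so what either group does elsewhere on that ring is unknown.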